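Working notes on a cytotoxicity series, compounds 1 to 4

The source may report more compounds than this note shows. Statements on the series, on what has been measured and on what is new or still open speak of the compounds shown alone.

Measured in a functional assay on MCF7 cells (Homo sapiens) for cytotoxicity, read by WST assay, with a stated time of 72 h; on this read-out lower numbers stand for stronger inhibition and higher numbers for weaker inhibition:
compound 1 `O=C1Nc2c(ccc(F)c2F)C1(c1ccc(O)cc1)c1ccc(F)cc1` gives 2.6 nM
compound 2 `Cc1ccc(C2(c3ccc(O)cc3)C(=O)Nc3c2ccc(F)c3F)cc1` gives 1.7 nM
compound 3 `Cc1ccc2c(c1C)NC(=O)C2(c1ccc(O)cc1)C1CCCCCC1` gives 19 nM

Compound 3 stands highest of the three in this assay, beyond the scatter from both others; the difference between its core and the core of compound 2 is not broken down here. Compound 4 `Cc1c(F)ccc2c1NC(=O)C2(c1ccc(O)cc1)C1CCCCCC1` is not yet measured. From compound 3 to compound 4 the change is fluoro in place of methyl on an aromatic carbon. The same kind of change was made from compound 2 to compound 1, (fluoro in place of methyl on an aromatic carbon), where it gave a 1.5-fold higher number from compound 2 to compound 1 (0.18 log units; within the scatter). The places differ: in the earlier pair the carbon is para to a large group on a single ring, whereas in compound 4 it lies in a fused system, ortho to a methyl group. Because the earlier step of a 1.5-fold higher number from compound 2 to compound 1 (0.18 log units; within the scatter) lay within the scatter, a similar small step a 1.2-fold higher number from compound 3 to compound 4 (0.06 log units; within the scatter) is expected here. Compound 4 is estimated at 22 nM, between 8 nM and 55 nM.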

Compound 4, half-maximal inhibitory concentration: 20 nM
For compound 4 the middle estimate is 1.1-fold (0.04 log units) above the measured one; low and high end bracket the measured number.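

In this assay, fluoro in place of methyl on an aromatic carbon again gives a step within the scatter, with a 1.1-fold higher number from compound 3 to compound 4 (0.02 log units; within the scatter). The two steps do not differ beyond the scatter, so on these two cores the change carries over as a small step: the same change on two cores in this assay, a 1.5-fold higher number (0.18 log units; within the scatter) from compound 2 to compound 1 and a 1.1-fold higher number (0.02 log units; within the scatter) from compound 3 to compound 4, 1.5-fold (0.16 log units) apart, within the scatter of two such steps

Among the compounds shown here, this rests on only two pairs, which differ in both core and place, so it neither separates those two factors nor shows that the step stays small on other cores or at other places.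

The compounds shown leave open whether a chloro, a methoxy or an amine on this aromatic carbon would give a step beyond the scatter. Also open, as far as these compounds go, is whether fluoro in place of methyl stays this small in compounds carrying a carboxylic acid.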